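This account rests on a few compounds, and the source may have more. Where it says the series, first, only, none or still open, it means among the compounds named here.

For the measured compounds named here, compound 3, `O=C(Nc1ccc(Oc2ccc(-c3ncc[nH]3)cc2)cc1)Nc1cc(Br)cc(C(F)(F)F)c1`, gives 44.1% in a functional assay on A549 cells (Homo sapiens) for inhibition, read by MTT assay and WST assay, with a stated time of 72 h, tested at 10 uM (a lower number here means less inhibition of growth, a higher number more inhibition of growth at the concentration tested), the highest of the three numbers known here. Going by the values given here, compound 2, `O=C(Nc1ccc(Oc2ccc(-c3ncc[nH]3)cc2)cc1)Nc1cccc(C(F)(F)F)c1`, gives 30%, and the only measured single change is a number 14.1 percentage points higher from compound 2 to compound 3 (beyond the scatter). Compound 1, `CC(=O)Oc1sccc1NC(=O)Nc1ccc(Oc2ccc(-c3nccs3)cc2)cc1`, gives 6.78% and sits furthest from compound 3.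

Compound 4, `CC(=O)Oc1sccc1NC(=O)Nc1ccc(Oc2ccc(-c3ncc[nH]3)cc2)cc1`, arises from compound 3 by 2-acetoxythiophen-3-yl in place of 3-bromo-5-(trifluoromethyl)phenyl on an amide-type nitrogen. Among the compounds with values here, no measured step covers this exchange directly. Within the data shown here, the one measured step, from compound 2 to compound 3, concerns only a bromo added to the departing group and so says little about what replaces that group entirely. What bears on it more is compound 1, which carries the same 2-acetoxythiophen-3-yl group on the urea but differs from compound 4 in one other part of the shared core. In this assay compound 1 gives 6.78%, far lower than the number for compound 3. On that basis compound 4 is expected to fall well short of compound 3, with a drop of a number 32.1 percentage points lower from compound 3 to compound 4 (beyond the scatter) expected. Compound 4 is therefore estimated at 12%, with a likely range from 2% to 28%.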

Compound 4, percent growth inhibition at one concentration: 2.34%
For compound 4 the middle estimate is 9.7 percentage points above the measured one; measured number inside the range.
By their numbers in this assay, from the lowest: compounds 4 and 1 (each within the scatter of the next); then compound 2; then compound 3.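

In this assay, 2-acetoxythiophen-3-yl in place of 3-bromo-5-(trifluoromethyl)phenyl on an amide-type nitrogen gives a number 41.8 percentage points lower from compound 3 to compound 4 (beyond the scatter) and thus shows that this position is sensitive to the group it carries. The same group in place of 3-(trifluoromethyl)phenyl gives a number 27.7 percentage points lower from compound 2 to compound 4 (beyond the scatter) and confirms the direction of the change, so the drop does not depend on the bromo alone. The other single exchange, 1H-imidazol-2-yl in place of 1,3-thiazol-2-yl on an aromatic carbon, gives a number 4.4 percentage points lower from compound 1 to compound 4 (within the scatter) and shows that these two rings cannot be told apart here while 2-acetoxythiophen-3-yl sits on the nitrogen.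

The compounds shown leave open whether the lower numbers follow from the acetoxy group or from the ring that carries it, which a plain thiophen-3-yl group or a 3-aminophenyl group at the same nitrogen could help to separate. They also leave open whether 1,3-thiazol-2-yl and 1H-imidazol-2-yl would still match with 3-(trifluoromethyl)phenyl in that place, and no measurement here explains the drop.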